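Chain extension on the aminoalkoxy side chain of the shared core

The compounds below may be only part of what the source reports. "The series", "measured", "known", "first", "only" and "open" are said of these compounds alone.

Measured compounds:
compound 1 `C#CCN(C)CCCCOc1ccc2c(c1)OCCC2=O`: 22.8%
compound 2 `C#CCN(C)CCCCCOc1ccc2c(c1)OCCC2=O`: 6.04%

In an ADME assay on BTI cells for inhibition of Amine oxidase [flavin-containing] A (Homo sapiens), read by fluorescence and Amplex Red, with a stated time of 15 min, tested at 100 uM (on this read-out higher numbers stand for more inhibition at the one concentration tested (going by the name of the read-out) and lower numbers for less inhibition), compound 2 gives the lower of the two numbers, the step being a number 16.8 percentage points lower from compound 1 to compound 2 (beyond the scatter). Compound 3 `C#CCN(C)CCCCCCOc1ccc2c(c1)OCCC2=O` extends the chain once more: (methyl(propargyl)amino)methyl in place of methyl(propargyl)amino on a saturated chain carbon, five bonds along the chain from an oxygen on an aromatic ring. Among the measured compounds shown here, only this one step bears on the change, and it was modest but beyond the scatter, downward. Compound 2 already sits near the bottom of the scale, so the expected step of a number 3 percentage points lower from compound 2 to compound 3 (within the scatter) is a further small drop, bounded by zero. For compound 3 the estimate in this assay is 3%, within -5% to 12%.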

Compound 3, a percentage reported as inhibition, at one concentration (the size of the read-out at that concentration, not a potency): 34.1%
Compound 3: middle estimate off by 31.1 percentage points, on the low side; measured number above the stated range.
By their numbers in this assay, from the lowest: compound 2; then compound 1; then compound 3.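

Lengthening the chain does not steadily erode the read-out in this assay: the direction reverses, with a number 28.1 percentage points higher from compound 2 to compound 3 (beyond the scatter), and the longest chain shown also finishes past the shortest, with a number 11.3 percentage points higher from compound 1 to compound 3 (beyond the scatter). Across these compounds the number dips at compound 2, so no single trend with chain length holds. Nothing available bears on why the number turns upward.

From the compounds shown here alone, whether a longer chain extends the rise or reverses it stays open. So does whether the pattern persists with dimethylamino in place of methyl(propargyl)amino.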